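Phenyl in place of (pyridin-3-yl)methyl on a sulfur

This account rests on a few compounds, and the source may have more. Where it says the series, first, only, none or still open, it means among the compounds named here.

In a functional assay on HCC827 cells (Homo sapiens) for antiproliferative activity, read by MTT assay, with a stated time of 72 h (a higher number here means a weaker inhibitor, a lower number a stronger inhibitor), compound 1 `CN1CCN(c2ccc(Nc3ncc4nc(SCc5cccnc5)n(C5CCCC5)c4n3)cc2)CC1` gives 517 nM and compound 2 `CN1CCN(c2ccc(Nc3ncc4nc([S+]([O-])Cc5cccnc5)n(C5CCCC5)c4n3)cc2)CC1` gives 2350 nM. For the measured compounds named here, that second figure is the higher of the only two numbers available, which makes compound 2 the weaker of the pair. Compound 3 `CN1CCN(c2ccc(Nc3ncc4nc([S+]([O-])c5ccccc5)n(C5CCCC5)c4n3)cc2)CC1` has not yet been measured. It shares its core with compound 2, and the change is phenyl in place of (pyridin-3-yl)methyl on a sulfur.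

Going by the values given here, only one measured step exists, a 4.5-fold higher number from compound 1 to compound 2 (0.66 log units; beyond the scatter). It is modest and reflects a different change, so it bears on this one only indirectly, showing that alterations in this part of the molecule can move the number beyond the scatter. Among the compounds with values here, no measured compound carries phenyl on the sulfur, so the data give no direction for this replacement. The expectation therefore stays close to compound 2 at 2350 nM, with no step beyond the scatter anticipated, though the range is kept wide. The expected step is a 1.1-fold lower number from compound 2 to compound 3 (0.03 log units; within the scatter). Compound 3 is estimated at 2200 nM, with an expected range of 800 nM to 6000 nM.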

Compound 3, half-maximal inhibitory concentration: 64.7 nM
Compound 3: middle estimate off by 34-fold (1.53 log units), on the high side; measured number outside the range, below it.
By their numbers in this assay, from the lowest: compound 3; then compound 1; then compound 2.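

In this assay, for the compounds shown here, the group on this sulfur turns out to have a strong hold on the number: there is a 36-fold lower number from compound 2 to compound 3 (1.56 log units; beyond the scatter), a large step for phenyl in place of (pyridin-3-yl)methyl, where the only earlier step in this part of the molecule was modest. The oxygen on the sulfur, which came with the weaker number in compound 2, therefore does not by itself fix a weak number, since the comparison with the sulfur-linked (pyridin-3-yl)methyl group of compound 1 shows an 8.0-fold lower number from compound 1 to compound 3 (0.90 log units; beyond the scatter), with the oxygen and phenyl entering together. Nothing available explains why this replacement produces a step of this size.

The change removes the ring nitrogen and the carbon link to the sulfur at once, so these compounds cannot show which of the two matters; benzyl or pyridin-3-yl on the same sulfur would separate them. Also open, as far as these compounds go, is how phenyl behaves on a sulfur without its oxygen, and whether a methoxyphenyl or chlorophenyl group would carry the number further in either direction.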